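This account rests on a few compounds, and the source may have more. Where it says the series, first, only, none or still open, it means among the compounds named here.

Measured so far in a functional assay on U-251 cells (Homo sapiens) for antiproliferative activity, read by MTT assay, with a stated time of 72 h; on this read-out lower numbers stand for stronger inhibition and higher numbers for weaker inhibition:
- Compound 1 `O=C(Nc1ccc(Cl)c(-c2nnc3c(Cl)cccn23)c1)c1ccc(Cl)cc1` gives > 100000 nM, a limit of the assay.
- Compound 2 `O=C(Nc1ccc(Cl)c(-c2nnc3c(Cl)cccn23)c1)c1cccc(Cl)c1` gives 43100 nM.
- Compound 3 `Cc1cc(Cl)ccc1C(=O)Nc1ccc(Cl)c(-c2nnc3c(Cl)cccn23)c1` gives > 100000 nM, again a limit of the assay.

Compound 3 thus sits at the assay ceiling, where two of the three values sit (the limit of > 100000 nM in this assay, at which 2 of the 3 values shown sit). Only compound 2 gives a number; the step of an at least 2.3-fold higher number from compound 2 to compound 3 (0.36 log units; beyond the scatter) is at least modest, and the step that the two limits leave unreadable from compound 1 to compound 3 cannot be sized. Compound 4 `O=C(Nc1ccc(Cl)c(-c2nnc3c(Cl)cccn23)c1)c1ccccc1` is not yet measured. The change is phenyl in place of 4-chloro-2-methylphenyl on a carbonyl carbon. Among the measured compounds shown here, two measured steps bear on it: an at least 2.3-fold higher number from compound 2 to compound 3 (0.36 log units; beyond the scatter), which shows that carrying the 4-chloro-2-methylphenyl on the carbonyl carbon reaches the limit, and an at least 2.3-fold lower number from compound 1 to compound 2 (0.36 log units; beyond the scatter), which shows at least a modest drop in number on moving the chlorine from 4-chlorophenyl to 3-chlorophenyl. Neither tells what an unsubstituted phenyl does; the unsubstituted case has no measured neighbour. Weak activity is expected, near the limit. Compound 4 is estimated at 80000 nM, within 25000 nM to 200000 nM. The expected step is an at least 1.2-fold lower number from compound 3 to compound 4 (0.09 log units; that floor lies within the scatter), close to none beyond the scatter.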

Compound 4, half-maximal inhibitory concentration: 73500 nM
Beside the measured number, compound 4's estimate is 1.1-fold (0.04 log units) above it; low and high end bracket the measured number.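

In this assay, the unsubstituted phenyl on the carbonyl carbon yields a measured number, so a chloro on this ring is not required to obtain one; the step is a 1.7-fold higher number from compound 2 to compound 4 (0.23 log units; within the scatter), which leaves the 3-chlorophenyl and the phenyl not told apart. Against the two compounds at the limit, the steps are an at least 1.3-fold lower number from compound 3 to compound 4 (0.13 log units; that floor lies within the scatter) and an at least 1.3-fold lower number from compound 1 to compound 4 (0.13 log units; that floor lies within the scatter), and neither floor establishes a separation. The ceiling therefore still shapes what can be read in this small set: the limit of > 100000 nM in this assay, at which 2 of the 4 values shown sit.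

Open, as far as these compounds go, is whether any other group on the carbonyl carbon brings the number well down, for example a phenyl carrying an amine or a carboxylic acid, or a longer alkyl chain. Also open, from the compounds shown here alone, is whether the chloro or the methyl of the 4-chloro-2-methylphenyl matters more on its own.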